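Aryltriazene carboxamides: swapping a hydroxyethyl arm for allyl

The compounds below may be only part of what the source reports. "The series", "measured", "known", "first", "only" and "open" are said of these compounds alone.

Measured compounds:
Compound 1, `CN(C)/N=N/c1ccc(S(N)(=O)=O)cc1C(N)=O`: 3.32
Compound 2, `CN(CCO)/N=N/c1ccccc1C(N)=O`: 3.07

In a functional assay on L1210 cells (Mus musculus) for antiproliferative activity (on this read-out lower numbers stand for lower potency and higher numbers for higher potency (the scale is a negative logarithm)), compound 1 gives 3.32 and compound 2 gives 3.07. Compound 2 holds the lower of the two numbers, but the gap to compound 1 lies within the usual scatter, so the two cannot be told apart on these data.

Compound 3, `C=CCN(C)/N=N/c1ccccc1C(N)=O`, has not yet been measured. It differs from compound 2 in one place: vinyl in place of hydroxymethyl on a saturated chain carbon bound to an amine nitrogen. Among the measured compounds shown here, no measured pair shows the effect of this exchange, so the change can only be judged from compound 2 itself.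

Without such a reference, I expect no step beyond the scatter; the estimated step is a number 0.08 log units higher from compound 2 to compound 3 (within the scatter). Compound 3 is therefore estimated at 3.15, within a range from 2.65 to 3.65.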

Compound 3, logarithm of the reciprocal of the active concentration, log(1/C): 3.43
Estimate against measurement, compound 3: 0.28 log units below, and the stated range covers the measured number.
By their numbers in this assay, from the lowest: compounds 2, 1 and 3 (each within the scatter of the next, the first and the last beyond it).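

Among the compounds shown here, this pair gives the first measured look at the arm on the amine nitrogen: in this assay the change from 2-hydroxyethyl to allyl gives a number 0.36 log units higher from compound 2 to compound 3 (beyond the scatter) and so moves the number by more than the usual scatter. The arm is therefore a place where an exchange of this size can register on this read-out, although the step is modest and rests on this one pair alone. No measurement shown here accounts for the step.

The compounds shown leave open whether the step goes with the loss of the hydroxyl or with the arrival of the double bond, and a saturated propyl chain in the same place would separate the two. Also open, from the compounds shown here alone, is how a longer chain or a terminal amine on this arm would read.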